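Allyl to isobutyl carbamate: expected growth inhibition of compound 4

The source may hold more compounds than are shown below. What is called first, only, known or untested is meant among the compounds shown, and "the series" means these compounds.

Measured compounds:
- compound 1, `C=CCOC(=O)Nc1ccc([Se]C#N)cc1`: 5000 nM
- compound 2, `O=C(Nc1ccc([Se][Se]c2ccc(NC(=O)Oc3ccccc3)cc2)cc1)Oc1ccccc1`: 4500 nM
- compound 3, `CCOC(=O)Nc1ccc([Se][Se]c2ccc(NC(=O)OCC)cc2)cc1`: 5700 nM

Three compounds have been run in an ADME assay on 184B5 cells (Homo sapiens) for cytotoxicity, read by MTT assay, with a stated time of 72 h; on this read-out lower numbers stand for stronger inhibition of growth and higher numbers for weaker inhibition of growth. Compound 1 gives 5000 nM, compound 2 gives 4500 nM and compound 3 gives 5700 nM. Compound 1 stands second highest of the three numbers, but its nearest neighbour compound 2 and its furthest neighbour compound 3 both lie within the scatter of it, so the three values are indistinguishable and no order among them can be read. Going by the values given here, compounds 2 and 3 also carry a different core from compound 1, so they offer no step on the substituent of interest.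

Compound 4, `CC(C)COC(=O)Nc1ccc([Se]C#N)cc1`, has not yet been run in this assay. It differs from compound 1 as follows: isopropyl in place of vinyl on a saturated chain carbon bound to an oxygen next to a carbonyl group. Among the compounds with values here, no measured pair shows this change or any other single change, so the expected size of the step rests on general experience alone: a small shift in either direction, most likely none beyond the scatter of this assay.

Compound 4 is therefore expected to give about 5000 nM in this assay, within 2500 nM to 10000 nM, which means an expected step of no change at the digits printed from compound 1 to compound 4 (within the scatter).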

Compound 4, concentration for 50% growth inhibition: 5800 nM
For compound 4 the middle estimate is 1.2-fold (0.06 log units) below the measured one; measured number inside the range.
By their numbers in this assay, from the lowest: compounds 2, 1, 3 and 4 (each within the scatter of the next).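

Going by these compounds alone, with isopropyl in place of vinyl on a saturated chain carbon bound to an oxygen next to a carbonyl group, this assay gives a 1.2-fold higher number from compound 1 to compound 4 (0.06 log units; within the scatter) as the first step that isolates a single place. Within this one pair, therefore, going from allyl to isobutyl removes the double bond outside aromatic rings and adds one heavy atom without a change in the read-out beyond the scatter, so the double bond is not needed to keep the value of compound 1 in this assay. No independent data bear on why this place accepts the change.

As far as these compounds go, whether a longer chain, a phenyl ring, an amine or a carboxylic acid in this place would move the number in this assay beyond the scatter remains open, as one step spans only a narrow range of groups. Compound 2 and compound 3 carry a different core and different groups from compound 1, so steps between them and the compounds on the shared core cannot be read, and the contribution of the core itself remains unresolved.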